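From a Propyl Amide to a Tert-Butyl Amide

The source may report more compounds than this note shows. Statements on the series, on what has been measured and on what is new or still open speak of the compounds shown alone.

Compound 1, `C=CC1=C(C(=O)NCCC)C(c2ccc(Cl)c(Cl)c2)OC1`, gives 31300 nM in a functional assay on QGY7701 cells (Homo sapiens) for cytotoxicity, read by MTT assay, with a stated time of 24 h; a higher number here means a weaker inhibitor, a lower number a stronger inhibitor.
Compound 2, `C=CC1=C(C(=O)NCc2ccccc2F)C(c2ccc(F)cc2)OC1`, gives 51400 nM in this assay.
Compound 3, `C=CC1=C(C(=O)Nc2ccc(OCC)cc2)C(c2ccc(OC)cc2)OC1`, reaches only the assay limit of > 100000 nM in this assay.

Of the two numbers shown, that of compound 1 is the smaller, but compound 2 sits within the usual scatter of it, so the two cannot be told apart. Compound 4, `C=CC1=C(C(=O)NC(C)(C)C)C(c2ccc(Cl)c(Cl)c2)OC1`, differs from compound 1 in one place: tert-butyl in place of propyl on an amide-type nitrogen. Among the measured compounds shown here, no measured pair shows such a change, so there is no basis for expecting a shift beyond the scatter in either direction. Compound 4 is therefore estimated at 35000 nM, between 12000 nM and 100000 nM. The step of a 1.1-fold higher number from compound 1 to compound 4 (0.05 log units; within the scatter) is expected to amount to nothing beyond the scatter. A limit rather than a number remains possible, since the limit of > 100000 nM in this assay, at which 1 of the 3 values shown sits, shows where one of the three values sits.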

Compound 4, half-maximal inhibitory concentration: > 100000 nM
Compound 4: only a limit was reported (the forecaster's own chance of this, stated with the estimate: 25%); middle value at least 2.8-fold (0.45 log units) from the limit.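

Among the compounds shown here, the amide-type nitrogen is the first place in this set where a single change can be read: in this assay, tert-butyl in place of propyl gives an at least 3.1-fold higher number from compound 1 to compound 4 (0.50 log units; beyond the scatter) on the otherwise unchanged core. This position is therefore sensitive to the group it carries, at least in this one pair. The result for compound 4 is a limit and not a number: the limit of > 100000 nM in this assay, at which 2 of the 4 values shown sit.

From the compounds shown here alone, how far compound 4 truly lies from compound 1 remains open. So does whether an unbranched butyl chain or an isopropyl group on this nitrogen would read like propyl or like tert-butyl.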